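Replacing pyridin-4-yl with phenyl in compound 3

The source may hold more compounds than are shown below. What is called first, only, known or untested is meant among the compounds shown, and "the series" means these compounds.

- compound 1 `CN1CCC(C(=O)N2Cc3c(NC(=O)c4cc(F)cc(F)c4)n[nH]c3C2(C)C)CC1`: 130 nM
- compound 2 `CN1CCC(C(=O)N2Cc3c(NC(=O)c4ccncc4)n[nH]c3C2(C)C)CC1`: 500 nM

Both values come from a functional assay on A2780 cells (Homo sapiens) for antiproliferative activity, read by fluorescence, with a stated time of 72 h; on this read-out higher numbers stand for weaker inhibition and lower numbers for stronger inhibition. Compound 2 has the higher of the two numbers, so it is the weaker inhibitor of the pair. For the measured compounds named here, the only measured step is a 3.8-fold higher number from compound 1 to compound 2 (0.59 log units; beyond the scatter), and it is beyond the usual scatter.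

Compound 3 `CN1CCC(C(=O)N2Cc3c(NC(=O)c4ccccc4)n[nH]c3C2(C)C)CC1` differs from compound 2 by one change: phenyl in place of pyridin-4-yl on a carbonyl carbon. Going by the values given here, no measured step makes exactly this swap, so the step above is the closest guide. Compound 3 carries a ring of carbon only, as compound 1 does, although phenyl is not 3,5-difluorophenyl. Part of that step may therefore be regained, but perhaps not all of it. The expected step is a 1.9-fold lower number from compound 2 to compound 3 (0.28 log units; within the scatter), towards stronger inhibition. For compound 3 the estimate is 260 nM, with an expected range from 110 nM to 600 nM.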

Compound 3, half-maximal inhibitory concentration: 160 nM
Estimate against measurement, compound 3: 1.6-fold (0.21 log units) above; measured number inside the range.
By their numbers in this assay, from the lowest: compounds 1 and 3 (each within the scatter of the next); then compound 2.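

In this assay, the ring nitrogen of pyridin-4-yl marks the difference at this position: with phenyl on the same carbonyl carbon there is a 3.1-fold lower number from compound 2 to compound 3 (0.49 log units; beyond the scatter) on swapping that one ring atom for carbon. The fluorines add nothing that can be told apart here, since there is only a 1.2-fold higher number from compound 1 to compound 3 (0.09 log units; within the scatter) on going to the plain phenyl, so the earlier gain of compound 1 over compound 2 can be matched without them. No measurement in hand gives a reason for either step.

Going by these compounds, it remains open whether a nitrogen elsewhere in the ring, as in pyridin-3-yl, would give a similar step to that of pyridin-4-yl. The compounds shown also leave open what a methoxy group or an amine on the phenyl ring would do to the number.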